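Losing the thiophene sulfonamide from compound 2

This account rests on a few compounds, and the source may have more. Where it says the series, first, only, none or still open, it means among the compounds named here.

Compound 1 `O=C(NC[C@H](NS(=O)(=O)c1cccs1)C(=O)O)c1cc2cc(CCC3CCNCC3)sc2s1` gives 9 nM
Compound 2 `O=C(NC[C@H](NS(=O)(=O)c1cccs1)C(=O)O)c1cc2sc(CCC3CCNCC3)cc2s1` gives 13 nM

In a functional assay for inhibition, with Homo sapiens as the target (on this read-out lower numbers stand for stronger inhibition and higher numbers for weaker inhibition), compound 2 gives 13 nM and stands within the scatter of compound 1 at 9 nM in the same read-out, so the two cannot be told apart on these numbers. Both carry the same side chain and differ only in the shared core.

Compound 3 `O=C(O)CCNC(=O)c1cc2sc(CCC3CCNCC3)cc2s1` departs from compound 2 at one place: hydrogen in place of ((thiophen-2-yl)sulfonyl)amino on a saturated chain carbon bound to a carbonyl carbon and a saturated chain carbon. For the measured compounds named here, no measured pair tests this change, so its size has to be judged without a direct precedent. Going by the values given here, compound 2 at 13 nM holds a low number with the group in place, and nothing measured so far shows that this number survives without it. A clear step towards weaker inhibition in this assay is therefore expected, beyond the scatter, and the estimated change is a 12-fold higher number from compound 2 to compound 3 (1.06 log units; beyond the scatter) in this read-out. For compound 3 the expected value is 150 nM within an estimated range of 40 nM to 600 nM in this read-out.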

Compound 3, half-maximal inhibitory concentration: 500 nM
Beside the measured number, compound 3's estimate is 3.3-fold (0.52 log units) below it; the range from low to high includes it.
By their numbers in this assay, from the lowest: compounds 1 and 2 (each within the scatter of the next); then compound 3.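

In this assay, hydrogen in place of ((thiophen-2-yl)sulfonyl)amino on a saturated chain carbon bound to a carbonyl carbon and a saturated chain carbon brings a 38-fold higher number from compound 2 to compound 3 (1.59 log units; beyond the scatter), a large step and the only one so far that reads this position. Compounds 1 and 2 both carry the group, so they could speak only to the shared core; the new step shows that much of the low number of compound 2 depends on the group being present, while compound 3 , at 500 nM, still gives a measured number in the nanomolar range without it. Nothing available accounts for the size of this step, so the result stands as an observation without an explanation.

As far as these compounds go, what stays open is which part of the departing group matters, the thiophene ring, the sulfonyl or the nitrogen, since all of them leave together in this one change. A plain amine, an acetylamino group or a (phenylsulfonyl)amino group on the same carbon would divide the step into its parts, and the same loss on the core of compound 1 would show whether its size carries over.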